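A Larger Ring Group Replaces the Nitrile on the Benzyl Ether

A few compounds are considered here, and "the series" means these few. Any claim that something is new, unique, unknown or untested is made for them only; others in the source may bear on it.

Compound 1, `CC(C)(N)C(=O)N[C@H](COCc1ccc(F)cc1F)c1nnnn1CCOC(=O)NCCCCO`, gives 0.42 nM in a functional assay on cells for inhibition of growth hormone secretagogue receptor type 1 (Homo sapiens), read by FLIPR and calcium flux; a lower number here means that less compound is needed, a higher number that more compound is needed for the effect.
Compound 2, `CC(C)(N)C(=O)N[C@H](COCc1cc(Cl)cc(Cl)c1)c1nnnn1CCOC(=O)NCCCCO`, gives 6.75 nM.
Compound 3, `CC(C)(N)C(=O)N[C@H](COCc1ccccc1C#N)c1nnnn1CCOC(=O)NCCCCO`, gives 1.26 nM.

Compound 3 therefore sits in the middle of the three: a 3.0-fold higher number from compound 1 to compound 3 (0.48 log units; beyond the scatter), while a 5.4-fold lower number from compound 2 to compound 3 (0.73 log units; beyond the scatter). The next compound alters only the substituent on the phenyl ring of this benzyl ether. In compound 4, `Cc1noc(C)c1-c1ccccc1COC[C@@H](NC(=O)C(C)(C)N)c1nnnn1CCOC(=O)NCCCCO`, the change is 3,5-dimethyl-1,2-oxazol-4-yl in place of cyano on an aromatic carbon, at the place described as ortho to a large group. Within the data shown here, no measured step adds a second ring at this position, so the guide is only how much the number moved when the ring substitution pattern was varied: modestly in the two steps above, and more in a 16-fold higher number from compound 1 to compound 2 (1.21 log units; beyond the scatter). A new five-membered aromatic ring is a larger change than any of those, so a shift beyond the scatter toward a higher number is expected, though its size is uncertain. For compound 4 the estimate is 3.5 nM, with a range of 0.7 nM to 18 nM, which is expected to mean a 2.8-fold higher number from compound 3 to compound 4 (0.44 log units; beyond the scatter).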

Compound 4, half-maximal effective concentration: 1.04 nM
Compound 4: middle estimate off by 3.4-fold (0.53 log units), on the high side, and the stated range covers the measured number.
By their numbers in this assay, from the lowest: compound 1; then compounds 4 and 3 (each within the scatter of the next); then compound 2.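

In this assay, putting 3,5-dimethyl-1,2-oxazol-4-yl in place of cyano gives a 1.2-fold lower number from compound 3 to compound 4 (0.08 log units; within the scatter). The earlier compounds shown here varied only small groups on this phenyl ring, so they could not show that an aromatic carbon ortho to a large group can carry a whole second ring with the number staying within the scatter of that of the nitrile compound. Nothing measured here explains why two such different groups give numbers this close.

Going by these compounds, whether this holds beyond these two groups remains open, and an amine, a carboxylic acid or a phenyl ring at the same place would test it. On these data alone, the role of the two methyl groups is also open, and a plain 1,2-oxazol-4-yl ring would address it.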